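A few compounds are considered here, and "the series" means these few. Any claim that something is new, unique, unknown or untested is made for them only; others in the source may bear on it.

Measured in a functional assay on Caco-2 cells (Homo sapiens) for inhibition, read by sulforhodamine B assay, with a stated time of 72 h; a lower number here means a stronger inhibitor, a higher number a weaker inhibitor:
- Compound 1 `CC(C)CNC(=C\C(=O)/C=C/c1ccc(O)cc1)/C=C/c1ccc(O)cc1`: 18500 nM
- Compound 2 `CCC(C)NC(=C\C(=O)/C=C/c1ccc(O)cc1)/C=C/c1ccc(O)cc1`: 5800 nM

Among the measured compounds shown here, compound 2 holds the lower number of the two in this assay, and compound 1 is the only neighbour it can be compared with. Compound 3 `O=C(/C=C(/C=C/c1ccc(O)cc1)NC1CCCCC1)/C=C/c1ccc(O)cc1`, not yet measured, keeps the shared core but carries cyclohexyl in place of sec-butyl on the amine nitrogen: cyclohexyl in place of sec-butyl on an amine nitrogen.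

For the measured compounds named here, only one measured step bears on this change. It lies at the same amine nitrogen, where sec-butyl took the place of isobutyl and gave a 3.2-fold lower number from compound 1 to compound 2 (0.50 log units; beyond the scatter), a modest step. Going by the values given here, no measured compound carries a ring at that place, so the direction remains open, and no step beyond the scatter is expected in this assay. The expected step is a 1.2-fold lower number from compound 2 to compound 3 (0.06 log units; within the scatter). For compound 3 the estimated value is 5000 nM, with an expected range of 2000 nM to 13000 nM.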

Compound 3, half-maximal inhibitory concentration: 6900 nM
Compound 3: the middle estimate sits 1.4-fold (0.14 log units) below what was measured; low and high end bracket the measured number.
By their numbers in this assay, from the lowest: compounds 2 and 3 (each within the scatter of the next); then compound 1.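

In this assay, the amine nitrogen also tolerates a six-membered non-aromatic ring of carbon only: cyclohexyl in place of sec-butyl gives a 1.2-fold higher number from compound 2 to compound 3 (0.08 log units; within the scatter) and so does not separate compound 3 from compound 2 in this assay. Cyclohexyl in place of isobutyl gives a 2.7-fold lower number from compound 1 to compound 3 (0.43 log units; beyond the scatter) and thus shows a second group at this nitrogen that stands apart from isobutyl in the same direction as sec-butyl. No supporting measurement is available to explain these numbers.

The compounds shown leave open whether a smaller ring such as cyclopentyl, or an unbranched chain such as n-butyl, would stay with compound 2 and compound 3 or fall nearer compound 1. They also leave open how an aromatic group such as benzyl, or a ring bearing a hydroxyl group, would read at this nitrogen.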